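This account rests on a few compounds, and the source may have more. Where it says the series, first, only, none or still open, it means among the compounds named here.

Within the data shown here, compound 1 `Cc1c(Cl)ccc(S(=O)(=O)N(C)CCOCC(=O)N(C)Cc2ccc(C3=NCCN3)cc2)c1Cl` gives 2.1 nM in an assay on HEK293 cells for displacement of a labelled ligand from B1 bradykinin receptor (Homo sapiens), read by scintillation counting (on this read-out higher numbers stand for weaker inhibition and lower numbers for stronger inhibition), the lowest of the two numbers known so far; compound 2 `COc1cc(C)c(S(=O)(=O)N(C)CCOCC(=O)N2CCC(C(O)CN(C)C)CC2)c(C)c1` gives 30 nM in this assay, a gap beyond the usual scatter. Compound 3 `CN(Cc1ccc(C2=NCCN2)cc1)C(=O)COCCN(C)S(=O)(=O)c1ccc(OC(F)(F)F)cc1` differs from compound 1 in one place: 4-(trifluoromethoxy)phenyl in place of 2,4-dichloro-3-methylphenyl on a sulfonyl sulfur. Among the measured compounds shown here, no measured pair shows this particular exchange, so its effect can only be guessed. The exchange is expected to weaken binding modestly, a step of a 4.8-fold higher number from compound 1 to compound 3 (0.68 log units; beyond the scatter) that lies beyond the scatter. Compound 3 is therefore estimated at 10 nM in this assay, with a likely range from 2 nM to 60 nM.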

Compound 3, inhibition constant: 85 nM
For compound 3 the middle estimate is 8.5-fold (0.93 log units) below the measured one; the whole stated range lies below it.
By their numbers in this assay, from the lowest: compound 1; then compound 2; then compound 3.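

On the sulfonyl sulfur, a single exchange of the aromatic group is enough to change binding strongly: in this assay, 4-(trifluoromethoxy)phenyl in place of 2,4-dichloro-3-methylphenyl gives a 40-fold higher number from compound 1 to compound 3 (1.61 log units; beyond the scatter) while the rest of the molecule stays the same. No available evidence accounts for this loss.

From the compounds shown here alone, whether it comes from losing the chlorines and methyl or from adding the trifluoromethoxy group remains open. An unsubstituted phenyl or a 4-chlorophenyl on the same sulfur would help separate these possibilities.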